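The compounds below may be only part of what the source reports. "The series", "measured", "known", "first", "only" and "open" are said of these compounds alone.

Measured compounds:
Compound 1 `CCOC(=O)C1=Cc2ccccc2OC1(OCc1cc(-c2ccc(F)cc2F)no1)C(F)(F)F`: in a functional assay on A549 cells (Homo sapiens) for inhibition, read by MTT assay, with a stated time of 24 h (on this read-out lower numbers stand for stronger inhibition and higher numbers for weaker inhibition), compound 1 reaches only the limit > 150000 nM.
Compound 2 `CCCCCCCCn1cc(COC2(C(F)(F)F)Oc3ccccc3C=C2C(=O)OCC)nn1`: in this assay compound 2 reaches only the limit > 150000 nM.

Each of these two values is a limit of the assay, not a number, and both sit at the limit of > 150000 nM in this assay, at which 2 of the 2 values shown sit. Compound 1 thus stands at the limit, alongside compound 2. Compound 3 `CCOC(=O)C1=Cc2ccccc2OC1(OCc1cc(-c2ccc3ccccc3c2)no1)C(F)(F)F` keeps the shared core and differs from compound 1 by naphthalen-2-yl in place of 2,4-difluorophenyl on an aromatic carbon. Among the compounds with values here, no measured pair tests this change. No step beyond the scatter is expected in this assay in either direction. Compound 3 is expected to sit near the limit as well, around 150000 nM, within 50000 nM to 300000 nM. The expected step is then a number no higher from compound 1 to compound 3 (the limit leaves the size open).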

Compound 3, half-maximal inhibitory concentration: > 150000 nM
Compound 3 gave a limit, no number (the forecaster's own chance of this, stated with the estimate: 80%); the middle value sits exactly at the limit.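

Compound 1 and compound 3 each give a limit of the assay rather than a number, so no step between them can be read: the limit of > 150000 nM in this assay, at which 3 of the 3 values shown sit.

The compounds shown leave open which structure, if any, would give a measurable value.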